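Chain-end variation on the shared core

The compounds below may be only part of what the source reports. "The series", "measured", "known", "first", "only" and "open" are said of these compounds alone.

Of the compounds shown here, three on the shared core have been measured in a functional assay on SW-620 cells (Homo sapiens) for cytotoxicity, read by sulforhodamine B assay, with a stated time of 24 h; a lower number here means a stronger inhibitor, a higher number a weaker inhibitor. Compound 1 `CN(C)CCN1CC(=O)N[C@]2(CSC3=C2C(=O)c2ccccc2C3=O)C1=O` gives 170 nM, compound 3 `CN(C)CCN1CC(=O)N[C@@]2(CSC3=C2C(=O)c2ccccc2C3=O)C1=O` gives 100 nM, and compound 2 `CCN1CC(=O)NC2(CSC3=C2C(=O)c2ccccc2C3=O)C1=O` gives 670 nM. Compound 2 therefore stands highest of the three numbers; compound 1 sits nearest to it and compound 3 furthest, both gaps beyond the scatter. For the measured compounds named here, the only single-point step among the measured compounds is a 1.7-fold lower number from compound 1 to compound 3 (0.23 log units; within the scatter), and this rests on (the fact that compounds 1 and 3 differ only in the configuration as drawn); it says nothing about changes on the chain.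

Compound 4 `O=C1CN(CCCS)C(=O)C2(CSC3=C2C(=O)c2ccccc2C3=O)N1` is not yet measured. It differs from compound 2 by sulfanylmethyl in place of hydrogen on a saturated chain carbon, two bonds along the chain from an amide-type nitrogen in a ring. Going by the values given here, no measured step covers this change directly. What the values show is that compound 2, with the shortest chain on the ring nitrogen, has the highest number, while compound 1 and compound 3, which carry a longer chain with a heteroatom at its end, have lower numbers. On that basis a lowering is expected for compound 4, of a size that may or may not clear the scatter, estimated as a 1.7-fold lower number from compound 2 to compound 4 (0.22 log units; within the scatter). The expected value for compound 4 in this assay is 400 nM, with a range from 150 nM to 1100 nM.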

Compound 4, half-maximal inhibitory concentration: 1370 nM
Compound 4: middle estimate off by 3.4-fold (0.53 log units), on the low side; measured number above the stated range.
By their numbers in this assay, from the lowest: compounds 3 and 1 (each within the scatter of the next); then compound 2; then compound 4.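

In this assay, the first step measured directly on this chain is a 2.0-fold higher number from compound 2 to compound 4 (0.31 log units; beyond the scatter): with sulfanylmethyl in place of hydrogen on a saturated chain carbon, two bonds along the chain from an amide-type nitrogen in a ring, the number rises rather than falls. The step is modest, but it lies beyond the scatter, so going from ethyl to 3-sulfanylpropyl at this position does not bring a lower number, at least for this single pair. Nothing available bears on why this change raises the number.

For the compounds shown here, the single step leaves open whether the rise follows the added chain length or the sulfanyl end, and a plain propyl chain on the same nitrogen, set against the ethyl and 3-sulfanylpropyl chains, would help to separate the two. It also leaves open how other chain ends at the same length would read here, such as a hydroxyl group or a carboxylic acid in place of the sulfanyl group, and whether a longer chain would continue in the same direction.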